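Mirror-image reversal of compound 3 at both stereocentres

A few compounds are considered here, and "the series" means these few. Any claim that something is new, unique, unknown or untested is made for them only; others in the source may bear on it.

Measured so far: compound 1 `C[C@H](C(=O)NC[C@H](COC(=O)C(C)(C)C)Cc1ccccc1)c1ccc(NS(C)(=O)=O)c(F)c1` gives 43 nM in an assay on CHO cells for displacement of a labelled ligand from transient receptor potential cation channel subfamily V member 1 (Rattus norvegicus); a lower number here means a stronger inhibitor, a higher number a weaker inhibitor; compound 2 `Cc1ccc(CC(CNC(=O)C(C)(C)c2ccc(NS(C)(=O)=O)cc2)COC(=O)C(C)(C)C)cc1C` gives 370 nM in this assay; compound 3 `C[C@@H](C(=O)NC[C@H](COC(=O)C(C)(C)C)Cc1ccccc1)c1ccc(NS(C)(=O)=O)c(F)c1` gives 298 nM in this assay.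

Compound 3 is the second highest of the three numbers. Its nearest neighbour is compound 2, whose number sits within the scatter of it, so the two cannot be told apart; compound 1 is the furthest, with a clearly lower number.

Compound 4 `C[C@H](C(=O)NC[C@@H](COC(=O)C(C)(C)C)Cc1ccccc1)c1ccc(NS(C)(=O)=O)c(F)c1` is the mirror image of compound 3: the two compounds have the same atoms and bonds and differ only in configuration as drawn: 2 of 2 stereo elements differ (all stereocentres are inverted: mirror images); a stereocentre at a saturated chain carbon is drawn R in compound 3 and S in compound 4; a stereocentre at a saturated chain carbon is drawn R in compound 3 and S in compound 4. Among the compounds with values here, the only measured step that touches configuration is a 6.9-fold higher number from compound 1 to compound 3 (0.84 log units; beyond the scatter), and that step rests on (the fact that compounds 1 and 3 differ only in the configuration as drawn). Within the data shown here, compound 4 shares with compound 1 the configuration at the stereocentre inverted in that step, but it also carries the other stereocentre inverted, for which no measured step exists. The expectation is therefore drawn mainly from compound 1 and compound 3, allowing for the unmeasured centre to pull in either direction. Compound 4 is expected to give 110 nM in this assay, within 30 nM to 450 nM, meaning an estimated 2.7-fold lower number from compound 3 to compound 4 (0.43 log units; beyond the scatter).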

Compound 4, inhibition constant: 16.5 nM
Beside the measured number, compound 4's estimate is 6.7-fold (0.82 log units) above it, and the stated range ends above it.
By their numbers in this assay, from the lowest: compound 4; then compound 1; then compounds 3 and 2 (each within the scatter of the next).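

In this assay, the second stereocentre now has a measured step of its own, a 2.6-fold lower number from compound 1 to compound 4 (0.42 log units; beyond the scatter), so inverting that centre alone moves the number beyond the scatter, and downward. Going from one mirror image to the other gives an 18-fold lower number from compound 3 to compound 4 (1.26 log units; beyond the scatter), a large step, and the two inversions run the same way along the series: the number falls from compound 3 to compound 1 and falls again from compound 1 to compound 4. Among these three compounds both centres therefore count, and the atoms and bonds play no part in these differences, as each comparison is purely one of shape: the fact that compounds 1 and 4 differ only in the configuration as drawn; likewise, (the fact that compounds 3 and 4 differ only in the configuration as drawn).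

Going by these compounds, whether the effect of one centre stays the same when the other is inverted remains open, and the one remaining combination of the two centres would settle that. Also open, on these data alone, is whether this preference for one arrangement survives when the ester is replaced by a free hydroxyl group or an amine, or when the methyl group on the stereocentre gives way to an ethyl group.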